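Removing One Methoxy from the Dimethoxyphenyl Ketone

The source may report more compounds than this note shows. Statements on the series, on what has been measured and on what is new or still open speak of the compounds shown alone.

Measured compounds:
compound 1, `COc1cc(-c2cc(/C=C/C(=O)c3ccc(N)cc3)[nH]n2)cc(OC)c1OC`, -57%
compound 2, `COc1ccc(C(=O)/C=C/c2cc(-c3cc(OC)c(OC)c(OC)c3)n[nH]2)cc1OC`, -88%

Two compounds share a core in which a trimethoxyphenyl-bearing pyrazole carries an enone. In a functional assay on SK-MEL-28 cells (Homo sapiens) for cytotoxicity, read by sulforhodamine B assay, with a stated time of 48 h, tested at 10 uM (on this read-out lower numbers stand for a stronger effect and higher numbers for a weaker effect at the one concentration tested), compound 1 gives -57%. Among the measured compounds shown here, compound 2 gives -88% in this assay, the lowest of the two numbers, and the only step measured so far runs a number 31 percentage points lower from compound 1 to compound 2 (beyond the scatter), exchanging the group on the carbonyl carbon.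

Compound 3, `COc1ccc(C(=O)/C=C/c2cc(-c3cc(OC)c(OC)c(OC)c3)n[nH]2)cc1`, has not yet been measured. It differs from compound 2 in one place: hydrogen in place of methoxy on an aromatic carbon.

For the measured compounds named here, no measured step removes a methoxy group from this ring; the one step known, from an aminophenyl to a dimethoxyphenyl ketone, concerns a different exchange and only shows that what sits on the carbonyl carbon can move the number far. The change from compound 2 to compound 3 is smaller than that exchange, so compound 3 is expected to remain close to compound 2, with at most a modest shift toward a weaker effect, a number 13 percentage points higher from compound 2 to compound 3 (beyond the scatter). In this assay compound 3 is therefore estimated at -75%, within a range from -95% to -50%.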

Compound 3, a percentage reported as activity, at one concentration (the size of the read-out at that concentration, not a potency): -55%
Compound 3: the middle estimate sits 20 percentage points below what was measured; measured number inside the range.
By their numbers in this assay, from the lowest: compound 2; then compounds 1 and 3 (each within the scatter of the next).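

In this assay, among the compounds shown here, the single methoxy group that separates 3,4-dimethoxyphenyl from 4-methoxyphenyl carries a large step by itself, a number 33 percentage points higher from compound 2 to compound 3 (beyond the scatter), so this place on an aromatic carbon, ortho to a methoxy group, is not a silent one, as the exchange of the whole group on the carbonyl carbon could not show. The other new step, a number 2 percentage points higher from compound 1 to compound 3 (within the scatter), shows that methoxy in place of amino on the aromatic carbon does not separate compound 1 from compound 3, and among these compounds only the 3,4-dimethoxyphenyl ketone of compound 2 stands apart. Nothing available explains why this one methoxy group counts for so much.

The three compounds leave open whether it is methoxy as such that matters at this place, or whether a hydroxyl group, a chlorine atom or an ethoxy group there would keep the number of compound 2. They also leave open whether the remaining methoxy group is needed, which a ketone carrying an unsubstituted phenyl ring or one with a single methoxy group at the vacated place would address.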